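Three tolerated limits and a piperazine amide

The source may report more compounds than this note shows. Statements on the series, on what has been measured and on what is new or still open speak of the compounds shown alone.

In an ADME assay on TZM cells (Homo sapiens) for cytotoxicity, with a stated time of 1 days (a higher number here means that more compound is tolerated, a lower number that less compound is tolerated), compound 1 `Cc1cc(C#N)cc(C)c1Oc1nc(Nc2ccc(C#N)cc2)ncc1/C=C/C(=O)NC1CCN(S(C)(=O)=O)CC1` gives > 175 nM, which is a limit of the assay and not a number. Compound 2 `Cc1cc(C#N)cc(C)c1Oc1nc(Nc2ccc(C#N)cc2)ncc1/C=C/C(=O)NC1CCN(S(=O)(=O)C(F)(F)F)CC1` gives > 160 nM in this assay, again a limit. Compound 3 `Cc1cc(C#N)cc(C)c1Oc1nc(Nc2ccc(C#N)cc2)ncc1/C=C/C(=O)NC1CCN(C(=O)C(F)(F)F)CC1` gives > 170 nM, also a limit. The three values sit at the limit of > 175 nM in this assay, at which 1 of the 3 values shown sits, the limit of > 160 nM in this assay, at which 1 of the 3 values shown sits, and (the limit of > 170 nM in this assay, at which 1 of the 3 values shown sits). Accordingly the step from compound 1 to compound 2 is a step that the two limits leave unreadable from compound 1 to compound 2, the step from compound 1 to compound 3 is a step that the two limits leave unreadable from compound 1 to compound 3, and the step from compound 2 to compound 3 is a step that the two limits leave unreadable from compound 2 to compound 3.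

Compound 4 `Cc1cc(C#N)cc(C)c1Oc1nc(Nc2ccc(C#N)cc2)ncc1/C=C/C(=O)N1CCN(C(=O)C(F)(F)F)CC1` carries a different change: 4-((trifluoromethyl)carbonyl)piperazin-1-yl in place of (1-(methylsulfonyl)piperidin-4-yl)amino on a carbonyl carbon. The measured steps that alter the same end of the molecule all lie between limits, so none of them gives a readable size or direction. Compound 4 is therefore expected to give 200 nM, with a range from 80 nM to 600 nM, most likely again as a limit. The step that the limit leaves unreadable from compound 1 to compound 4 is thus expected to be none beyond the scatter.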

Compound 4, half-maximal cytotoxic concentration: > 174 nM
Compound 4: no number, only a limit; the forecaster's own chance of this, stated with the estimate: 75%; the middle value does not contradict the limit.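

In this assay compound 4 gives > 174 nM, a limit of the assay and not a number. Compound 1 also stands only at a limit, and the step between them cannot be read. The compounds shown leave open at what concentration any of the four becomes cytotoxic.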